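The compounds below may be only part of what the source reports. "The series", "measured", "known", "first", "only" and "open" are said of these compounds alone.

Values measured so far in a functional assay on Huh-7 cells (Homo sapiens) for inhibition, read by MTT assay, with a stated time of 72 h; on this read-out lower numbers stand for stronger inhibition and higher numbers for weaker inhibition

- Compound 1 `Nc1nc2cc(-c3nn(CCCCCCCCCC(=O)NO)c4ncnc(N)c34)ccc2o1` gives 41200 nM
- Compound 2 `Nc1ncnc2c1c(-c1cnc3[nH]ccc3c1)nn2CCCCCCCCCC(=O)NO` gives 10100 nM
- Compound 3 `Nc1ncnc2c1c(-c1cnc3[nH]ccc3c1)nn2CCCCCCC(=O)NO` gives 50900 nM

Compound 1 and compound 3 lie within the usual scatter of each other, high on this scale. Swapping the aromatic group on the shared core gives a 4.1-fold lower number from compound 1 to compound 2 (0.61 log units; beyond the scatter) and that is the one clear drop here. The next compound is compound 4 `Nc1nc2cc(-c3nn(CCCCCC(=O)NO)c4ncnc(N)c34)ccc2o1` which keeps the core of compound 1 and shortens its chain. The change is hydroxycarbamoyl in place of 4-(hydroxycarbamoyl)butyl on a saturated chain carbon, five bonds along the chain from an aromatic nitrogen and the chain still ends in hydroxycarbamoyl.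

The closest guide is a chain cut of the same kind, with hydroxycarbamoyl in place of 3-(hydroxycarbamoyl)propyl, which gave a 5.0-fold higher number from compound 2 to compound 3 (0.70 log units; beyond the scatter) in this assay on the other aromatic group. That is a single pair, and the aromatic swap shows that this group can shift the numbers too, so the chain effect may not carry over in full. A somewhat smaller rise is therefore the cautious expectation. The step expected in this assay is a 3.2-fold higher number from compound 1 to compound 4 (0.50 log units; beyond the scatter) as an estimate, towards a higher number and weaker inhibition. The estimated value for compound 4 is 130000 nM within an expected range of 40000 nM to 400000 nM for now.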

Compound 4, half-maximal inhibitory concentration: 9910 nM
Compound 4: the middle estimate sits 13-fold (1.12 log units) above what was measured, and the stated range ends above it.
By their numbers in this assay, from the lowest: compounds 4 and 2 (each within the scatter of the next); then compounds 1 and 3 (each within the scatter of the next).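

In this assay, replacing 4-(hydroxycarbamoyl)butyl with hydroxycarbamoyl on the saturated chain gives a 4.2-fold lower number from compound 1 to compound 4 (0.62 log units; beyond the scatter), so a shorter chain ending in hydroxycarbamoyl can go with stronger inhibition. The earlier chain cut, hydroxycarbamoyl in place of 3-(hydroxycarbamoyl)propyl on the other aromatic group, went the opposite way, with a 5.0-fold higher number from compound 2 to compound 3 (0.70 log units; beyond the scatter), so a shorter chain does not bring the same change in every compound here, although the two cuts also differ in size. Nothing available explains this difference in direction.

With only two chain lengths shown on each aromatic group, it remains open how the numbers change at intermediate or still shorter chain lengths. Going by these compounds, it is also open how a carboxylic acid or an amine at the chain end, in place of hydroxycarbamoyl, would compare.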